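From methyl to nitro on compound 1

The source may hold more compounds than are shown below. What is called first, only, known or untested is meant among the compounds shown, and "the series" means these compounds.

Compound 1 `COc1ccc(/C=C2/CN(C)/C(=N/c3ccc(C)cc3)S2)cc1` at 65700 nM
Compound 2 `COc1ccc(/C=C2\S/C(=N\c3ccc(Cl)cc3)N(C)C2=O)cc1` at > 100000 nM

Among the measured compounds shown here, in an ADME assay on TERT-RPE1 cells (Homo sapiens) for cytotoxicity, read by MTT assay, with a stated time of 72 h (on this read-out lower numbers stand for stronger inhibition and higher numbers for weaker inhibition), compound 1 gives 65700 nM as the only actual number among the measured compounds. Compound 2 reads > 100000 nM as a limit of the assay and not a number. Compound 3 `COc1ccc(/C=C2/CN(C)/C(=N/c3ccc([N+](=O)[O-])cc3)S2)cc1` keeps the core of compound 1 and differs on an aromatic carbon of a six-membered aromatic ring of carbon only, para to a large group, with nitro in place of methyl on an aromatic carbon in that spot. For the measured compounds named here, no measured pair shows what such a change does, so the expectation rests on compound 1 at 65700 nM alone, and no step beyond the scatter is expected in this assay in either direction. The expected change is a 1.2-fold lower number from compound 1 to compound 3 (0.08 log units; within the scatter) and it stays within that scatter. Compound 3 is estimated at 55000 nM (expected range 18000 nM to 100000 nM).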

Compound 3, half-maximal inhibitory concentration: > 100000 nM
Compound 3: no number, only a limit; the forecaster's own chance of this, stated with the estimate: 25%; middle value at least 1.8-fold (0.25 log units) away from the limit.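

In this assay, nitro in place of methyl on an aromatic carbon, para to a large group, gives an at least 1.5-fold higher number from compound 1 to compound 3 (0.18 log units; that floor lies within the scatter), the first step read at this position. The value of compound 3, > 100000 nM, is a limit of the assay and not a number, so the pair fixes only a floor for the change, and that floor does not clear the usual scatter. The true size of the step stays unknown because the reading for compound 3 stops at the end of the range: the limit of > 100000 nM in this assay, at which 2 of the 3 values shown sit.

Still open, on these data alone, is whether an amine or a carboxylic acid at this position would keep the number near that of compound 1, 65700 nM, or move it in either direction. Compound 2 differs from compound 1 in more than one place, so it says nothing about this position alone.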